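Removing One Nitrooxy Group from the Longer-Lived Ester

The compounds below may be only part of what the source reports. "The series", "measured", "known", "first", "only" and "open" are said of these compounds alone.

Of the compounds shown here, three have so far been measured in a physicochemical assay for metabolic stability, read by HPLC; on this read-out higher numbers stand for a longer-lived compound and lower numbers for a shorter-lived compound. Compound 1 `Cc1cc(OC(=O)OCCCCCCO[N+](=O)[O-])n(-c2ccccc2)n1` gives 4 h, compound 2 `Cc1cc(OC(=O)OCCCCC(CO[N+](=O)[O-])O[N+](=O)[O-])n(-c2ccccc2)n1` gives 3.1 h, and compound 3 `Cc1cc(OC(=O)c2ccc(OCC(CO[N+](=O)[O-])O[N+](=O)[O-])cc2)n(-c2ccccc2)n1` gives 25 h, the highest of the three. Compound 2 and compound 1 differ in one place, (hydrogen in place of nitrooxy on a saturated chain carbon bound to two saturated chain carbons), and that change made a 1.3-fold higher number from compound 2 to compound 1 (0.11 log units; within the scatter). Compound 3 carries a different core from compound 2; the difference between the two cores is not broken down here. Compound 4 `Cc1cc(OC(=O)c2ccc(OCCCO[N+](=O)[O-])cc2)n(-c2ccccc2)n1` has not yet been measured. It differs from compound 3 by hydrogen in place of nitrooxy on a saturated chain carbon bound to two saturated chain carbons, the same change at the same place as before. Because the earlier instance gave a 1.3-fold higher number from compound 2 to compound 1 (0.11 log units; within the scatter), the step from compound 3 to compound 4 in this assay is expected to be a 1.2-fold higher number from compound 3 to compound 4 (0.08 log units; within the scatter). Compound 4 is therefore estimated to give 30 h.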

Compound 4, half-life: 35 h
The estimate for compound 4 lay 1.2-fold (0.07 log units) below the measured number; the range from low to high includes it.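

In this assay the change from nitrooxy to hydrogen on a saturated chain carbon bound to two saturated chain carbons gave a 1.3-fold higher number from compound 2 to compound 1 (0.11 log units; within the scatter) on one core and a 1.4-fold higher number from compound 3 to compound 4 (0.15 log units; within the scatter) on the other. Both pairs therefore agree that this change stays within the scatter on these two cores, but neither step shows a real rise in half-life, and two pairs set no rule for other cores. Nothing available here explains this result.

The compounds shown leave open how an amine or a carboxylic acid would read in place of the nitrooxy group on that carbon. They also leave open whether a longer chain on the core of compound 4 would keep the half-life in the same range.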